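The source may report more compounds than this note shows. Statements on the series, on what has been measured and on what is new or still open speak of the compounds shown alone.

Measured in a functional assay on K562 cells (Homo sapiens) for antiproliferative activity, read by MTT assay, with a stated time of 48 h; a higher number here means a weaker inhibitor, a lower number a stronger inhibitor:
- compound 1 `CCN(CC)Cc1ccc2c(c1O)-c1ccc(cc1O)CCc1ccc(O)c(c1)Oc1ccc(cc1)CC2`: 7860 nM
- compound 2 `Oc1ccc2cc1Oc1ccc(cc1)CCc1ccc(CN3CCCC3)c(O)c1-c1ccc(cc1O)CC2`: 4820 nM
- compound 3 `CCCCN(CCCC)Cc1ccc2c(c1O)-c1ccc(cc1O)CCc1ccc(O)c(c1)Oc1ccc(cc1)CC2`: > 20000 nM (a limit of the assay, not a number)

Compound 3 stands at the limit of > 20000 nM in this assay, at which 1 of the 3 values shown sits. Its true value is therefore unknown, and it offers only a floor to build on.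

Compound 4 `CCCCN(CCCC)Cc1cc2cc(c1O)Oc1ccc(cc1)CCc1ccc(CN(CCCC)CCCC)c(O)c1-c1ccc(cc1O)CC2` keeps the dibutylamino side chain of compound 3 and gains a second one: (dibutylamino)methyl in place of hydrogen on an aromatic carbon. The (dibutylamino)methyl group replaces hydrogen on an aromatic carbon, ortho to a hydroxy group.

Within the data shown here, no measured step adds a group at this place, so the evidence is indirect. The steps at hand only exchange the amine on the existing side chain. Between the two smaller amines the result is a 1.6-fold lower number from compound 1 to compound 2 (0.21 log units; within the scatter). Moving to dibutylamino gives an at least 2.5-fold higher number from compound 1 to compound 3 (0.40 log units; beyond the scatter) and an at least 4.1-fold higher number from compound 2 to compound 3 (0.61 log units; beyond the scatter). Both of these steps point to a higher number, and compound 4 carries dibutylamino twice, so no move to a clearly lower number is expected. A report of only a limit again seems somewhat more likely than not.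

For compound 4 the expected step is a step that the limit leaves unreadable from compound 3 to compound 4.

For compound 4 the estimate is 25000 nM, with an expected range from 8000 nM to 70000 nM.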

Compound 4, half-maximal inhibitory concentration: > 20000 nM
Compound 4 ended at the assay's limit; the forecaster's own chance of this, stated with the estimate: 60%; the middle value lies beyond the limit too.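

In this assay compound 4 gives > 20000 nM, which is a limit of the assay and not a number. Compound 3 also stands at a limit, so no step from compound 3 to compound 4 can be read: the limit of > 20000 nM in this assay, at which 2 of the 4 values shown sit.

The compounds shown leave open whether the added (dibutylamino)methyl group changes the antiproliferative activity at all.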